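Azidoalkyl chain length on the chloro-substituted core

The source may report more compounds than this note shows. Statements on the series, on what has been measured and on what is new or still open speak of the compounds shown alone.

Compound 1 `Cn1c(=O)c2ccccc2c(=O)n1CCN=[N+]=[N-]` and compound 2 `Cn1c(=O)c2ccccc2c(=O)n1CCCN=[N+]=[N-]` share one core; compound 3 `Cn1c(=O)c2c(Cl)cccc2c(=O)n1CCN=[N+]=[N-]` and compound 4 `Cn1c(=O)c2c(Cl)cccc2c(=O)n1CCCN=[N+]=[N-]` share a core that differs from it by chloro in place of hydrogen on an aromatic carbon. In a functional assay on aorta (Rattus norvegicus, strain Wistar) for inhibition (on this read-out lower numbers stand for an effect already at smaller amounts and higher numbers for an effect only at larger amounts of compound), compound 1 gives 10000 nM, compound 2 gives 2350 nM and compound 3 gives 4120 nM. Between compound 1 and compound 2 stands (azidomethyl in place of azido on a saturated chain carbon, two bonds along the chain from an aromatic nitrogen), with the step of a 4.3-fold lower number from compound 1 to compound 2 (0.63 log units; beyond the scatter). The core change shows the step of a 2.4-fold lower number from compound 1 to compound 3 (0.39 log units; beyond the scatter). Compound 4 carries azidomethyl in place of azido on a saturated chain carbon, two bonds along the chain from an aromatic nitrogen, the same change at the same place as between compound 1 and compound 2. The step of a 4.1-fold lower number from compound 3 to compound 4 (0.61 log units; beyond the scatter) is expected to sit beside a 4.3-fold lower number from compound 1 to compound 2 (0.63 log units; beyond the scatter), resting on that single pair carrying over to the core of compound 3. Compound 4 is therefore estimated at 1000 nM, within a range from 400 nM to 2500 nM.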

Compound 4, half-maximal effective concentration: 2330 nM
Estimate against measurement, compound 4: 2.3-fold (0.37 log units) below, within the range that was stated.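

In this assay, the chain change on the chloro-bearing core reads a 1.8-fold lower number from compound 3 to compound 4 (0.25 log units; within the scatter), and it does not separate from the same change on the core of compound 1: the same change on two cores in this assay, a 4.3-fold lower number (0.63 log units; beyond the scatter) from compound 1 to compound 2 and a 1.8-fold lower number (0.25 log units; within the scatter) from compound 3 to compound 4, 2.4-fold (0.38 log units) apart, within the scatter of two such steps. The chloro change on the longer chain reads a 1.0-fold lower number from compound 2 to compound 4 (0.00 log units; within the scatter), and it does not separate from the step on the shorter chain either: the same change on two cores in this assay, a 2.4-fold lower number (0.39 log units; beyond the scatter) from compound 1 to compound 3 and a 1.0-fold lower number (0.00 log units; within the scatter) from compound 2 to compound 4, 2.4-fold (0.38 log units) apart, within the scatter of two such steps. Going by these compounds alone, neither comparison shows a dependence on the core, but this does not establish that the chain change carries over intact, as each core offers a single pair and only the step on the core of compound 1 lies beyond the scatter.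

Open, going by these compounds, is how a longer chain, or an amine in place of the azido group, would read on either core. Also open, on these data alone, is how fluoro or methoxy in place of chloro on the same aromatic carbon would read.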